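Swapping a Tolyl Arm for a Styryl Chain

The source may hold more compounds than are shown below. What is called first, only, known or untested is meant among the compounds shown, and "the series" means these compounds.

Three sugar-bearing triazole compounds have been tested in a functional assay on HeLa cells (Homo sapiens) for cytotoxicity, read by sulforhodamine B assay, with a stated time of 48 h; on this read-out higher numbers stand for weaker inhibition and lower numbers for stronger inhibition. Compound 1, `CC(=O)OC[C@H]1O[C@@H](n2cc(Cn3cc(C(C)=O)c4ccccc43)nn2)[C@H](OC(C)=O)[C@@H](OC(C)=O)[C@@H]1OC(C)=O`, carries an acetyl-substituted indole on the shared core; in this assay compound 1 gives > 200000 nM, which is a limit of the assay and not a number. For the measured compounds named here, compound 2, `CC(=O)OC[C@H]1O[C@@H](n2cc(CN3C(=O)/C(=C/c4ccc(C)cc4)c4ccccc43)nn2)[C@H](OC(C)=O)[C@@H](OC(C)=O)[C@@H]1OC(C)=O`, carries an oxindole with a 4-methylphenyl arm on its double bond; in this assay compound 2 gives 85600 nM, the only plain number among the three. Compound 3, `CC(=O)OC[C@H]1O[C@@H](n2cc(CN3C(=O)/C(=C\c4ccc(C)cc4)c4ccccc43)nn2)[C@H](OC(C)=O)[C@@H](OC(C)=O)[C@@H]1OC(C)=O`, is the same molecule drawn with the other configuration at that double bond; in this assay compound 3 gives > 100000 nM, which is a limit of the assay and not a number. The step of an at least 1.1-fold higher number from compound 2 to compound 3 (0.06 log units; that floor lies within the scatter) is linked only to the fact that compounds 2 and 3 differ only in the configuration as drawn and stays within the scatter.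

Compound 4, `CC(=O)OC[C@H]1O[C@@H](n2cc(CN3C(=O)/C(=C/C=C/c4ccccc4)c4ccccc43)nn2)[C@H](OC(C)=O)[C@@H](OC(C)=O)[C@@H]1OC(C)=O`, changes compound 2 by 2-phenylethenyl in place of 4-methylphenyl on a double-bonded chain carbon bound to a double-bonded ring carbon. Going by the values given here, no measured step concerns such a chain, and the single measured step around compound 2 lies within the scatter, so compound 4 is expected to stay near compound 2, with the step of a 1.1-fold lower number from compound 2 to compound 4 (0.03 log units; within the scatter) estimated as no change beyond the scatter. Compound 4 is therefore estimated at 80000 nM, between 30000 nM and 200000 nM.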

Compound 4, half-maximal inhibitory concentration: > 100000 nM
Compound 4: no number, only a limit; the forecaster's own chance of this, stated with the estimate: 40%; middle value at least 1.2-fold (0.09 log units) away from the limit.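

In this assay compound 4 gives > 100000 nM, which is a limit of the assay and not a number. Unlike the earlier step, which concerned only the configuration as drawn, this one replaces the group itself on a double-bonded chain carbon bound to a double-bonded ring carbon, and it reads an at least 1.1-fold higher number from compound 2 to compound 4 (0.06 log units; that floor lies within the scatter), so 2-phenylethenyl in place of 4-methylphenyl brings no gain in inhibition. How far apart the two compounds really lie cannot be told from this result, and one fact caps what the step can say: the limit of > 100000 nM in this assay, at which 2 of the 4 values shown sit.

The compounds shown leave open whether any group at this place can move the number clearly away from that of compound 2, in either direction. As far as these compounds go, an amine or a carboxylic acid in place of 4-methylphenyl, or a chain longer than 2-phenylethenyl, would test this in this assay, and the other configuration of the double bond that carries the 2-phenylethenyl group also remains open.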